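This account rests on a few compounds, and the source may have more. Where it says the series, first, only, none or still open, it means among the compounds named here.

Measured so far in an ADME assay on RAW264.7 cells (Mus musculus) for cytotoxicity, read by MTT assay; a lower number here means a stronger inhibitor, a higher number a weaker inhibitor:
- compound 1 `Cc1cc(C(=O)/C=C/C=C/c2ccccc2)c(C)o1` gives > 100000 nM
- compound 2 `CN(C)c1ccc(/C=C/C=C/C(=O)c2ccc(F)cc2)cc1` gives > 100000 nM
- compound 3 `O=C(/C=C/C=C/c1ccc(O)cc1)c1ccc(O)cc1` gives > 100000 nM

Each of these entries is a limit of the assay and not a number. The three compounds share one reading: the limit of > 100000 nM in this assay, at which 3 of the 3 values shown sit. Compound 3 therefore stands at that limit, and no rank order can be drawn among the three.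

The next compound is compound 4 `O=C(/C=C/C=C/c1ccc(O)cc1O)c1ccc(O)cc1`, which differs from compound 3 by one change: hydroxy in place of hydrogen on an aromatic carbon. This places hydroxy in place of hydrogen on an aromatic carbon, ortho to a large group and meta to a hydroxy group.

No pair of measured compounds differs in one place, so the size of such a step in this assay has not been shown directly. No step beyond the scatter is expected, and a further report as a limit is the likeliest outcome. This expectation rests on the reading shared by all three measured compounds: the limit of > 100000 nM in this assay, at which 3 of the 3 values shown sit. The expected step is a number no higher from compound 3 to compound 4 (the limit leaves the size open). For compound 4 the estimated value is 100000 nM, with an expected range from 50000 nM to 200000 nM.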

Compound 4, half-maximal inhibitory concentration: > 100000 nM
Compound 4 was reported as a limit (the forecaster's own chance of this, stated with the estimate: 75%); the middle value lies on the limit itself.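

Compound 3 and compound 4 are both reported as limits and not as numbers, so no step can be read for hydroxy in place of hydrogen on an aromatic carbon: the limit of > 100000 nM in this assay, at which 4 of the 4 values shown sit. The compounds shown leave open what change to the shared core, if any, would give a measurable number in this assay.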